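Trimming the Ring Substituent on a Shared Core

The source may hold more compounds than are shown below. What is called first, only, known or untested is meant among the compounds shown, and "the series" means these compounds.

Compound 2 `CS(=O)(=O)Nc1ccc2c(c1)S(=O)(=O)N=C(C1=C(O)C3CCCC3N(CC3CCC3)C1=O)N2` was examined in an ADME assay on Huh-7 cells (Homo sapiens) for cytotoxicity, with a stated time of 72 h; on this read-out higher numbers stand for lower toxicity in this test and lower numbers for higher toxicity in this test. In this test compound 2 gives only a limit, > 33000 nM, which is not a number. Compound 1 `CC(C)(C)CCN1C(=O)C(C2=NS(=O)(=O)c3cc(NS(C)(=O)=O)ccc3N2)=C(O)C2CCCCC21` likewise reaches only a limit in this assay, giving > 33000 nM. Where compound 2 stands on the numbers shown is therefore simply at the limit, because of the limit of > 33000 nM in this assay, at which 2 of the 2 values shown sit.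

Compound 3 `CCN1C(=O)C(C2=NS(=O)(=O)c3cc(NS(C)(=O)=O)ccc3N2)=C(O)C2CCCC21` has not yet been measured in this assay. It differs from compound 2 in one place: methyl in place of cyclobutyl on a saturated chain carbon bound to an amide-type nitrogen in a ring. Among the compounds with values here, no step between two measured compounds exists against which this change could be gauged. Since both measured compounds sit at the same limit, the step is expected to be none beyond the scatter, as a number no higher from compound 2 to compound 3 (the limit leaves the size open). Compound 3 is therefore expected to give 33000 nM in this assay, with a range from 15000 nM to 100000 nM, and most likely to be reported again only as a limit.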

Compound 3, half-maximal cytotoxic concentration: > 33000 nM
Compound 3 ended at the assay's limit (the forecaster's own chance of this, stated with the estimate: 80%); the middle value lies on the limit itself.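

Compound 2 and compound 3 both end at a limit rather than a number in this assay, so no step between them can be read: the limit of > 33000 nM in this assay, at which 3 of the 3 values shown sit.

The compounds shown leave open how far the half-maximal cytotoxic concentration of each lies past that limit, and whether any change of this substituent on the shared core would give a readable value in this assay.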